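A few compounds are considered here, and "the series" means these few. Any claim that something is new, unique, unknown or untested is made for them only; others in the source may bear on it.

Measured compounds:
- Compound 1 `COc1cc(-n2cnc3ccc(-c4cccc(C)c4C)cc32)cc(OC)c1OC` — 3040 nM
- Compound 2 `COc1ccccc1-c1ccc2ncn(-c3cc(OC)c(OC)c(OC)c3)c2c1` — 5050 nM
- Compound 3 `COc1cc(-n2cnc3ccc(-c4cccc(C)c4)cc32)cc(OC)c1OC` — 1240 nM

All three were tested in a functional assay on SGC-7901 cells (Homo sapiens) for antiproliferative activity, read by MTT assay, with a stated time of 72 h; on this read-out higher numbers stand for weaker inhibition and lower numbers for stronger inhibition. Compound 3 gives the lowest number of the three: the step from compound 1 to compound 3 is a 2.5-fold lower number from compound 1 to compound 3 (0.39 log units; beyond the scatter), and the step from compound 2 to compound 3 is a 4.1-fold lower number from compound 2 to compound 3 (0.61 log units; beyond the scatter), so compound 3 is the strongest inhibitor among them.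

Compound 4 `COc1cc(-n2cnc3ccc(-c4ccc(C(C)=O)cc4)cc32)cc(OC)c1OC` has not yet been measured. It differs from compound 3 in one place: 4-acetylphenyl in place of 3-methylphenyl on an aromatic carbon. Among the compounds with values here, no measured step involves a 4-acetylphenyl group, so the change can only be judged indirectly. Both known steps onto the 3-methylphenyl ring gave modest lowerings, and compound 2, the only analogue whose aryl ring carries an oxygen, has the highest number shown. Going the other way from compound 3, a modest rise is therefore expected in this assay, a 2.3-fold higher number from compound 3 to compound 4 (0.35 log units; beyond the scatter), with wide uncertainty. Compound 4 is estimated at 2800 nM, in the range 900 nM to 9000 nM.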

Compound 4, half-maximal inhibitory concentration: 450 nM
For compound 4 the middle estimate is 6.2-fold (0.79 log units) above the measured one, and the stated range ends above it.
By their numbers in this assay, from the lowest: compound 4; then compound 3; then compounds 1 and 2 (each within the scatter of the next).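

In this assay the swap of 3-methylphenyl for 4-acetylphenyl on this aromatic carbon goes further down than any earlier change (a 2.8-fold lower number from compound 3 to compound 4 (0.44 log units; beyond the scatter)), which makes compound 4 the strongest inhibitor of the four. Against the other two rings the 4-acetylphenyl group also gives lower numbers (an 11-fold lower number from compound 2 to compound 4 (1.05 log units; beyond the scatter); a 6.8-fold lower number from compound 1 to compound 4 (0.83 log units; beyond the scatter)), and the first of these is large, so an oxygen on this ring does not by itself go with a high number, as the 2-methoxyphenyl ring alone had suggested. No measurement shown explains these differences.

The compounds shown leave open whether the gain belongs to the acetyl group or to its place on the ring; a 3-acetylphenyl ring and a 4-methylphenyl ring would separate the two. As far as these compounds go, how a 4-aminophenyl or 4-carboxyphenyl ring would compare also remains open.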